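The source may hold more compounds than are shown below. What is called first, only, known or untested is meant among the compounds shown, and "the series" means these compounds.

Four compounds share one core, a naphthalene-bearing pyridine ring. Compound 1 `CNC(=O)COc1ccncc1-c1ccc2ccccc2c1` carries a methylamide-bearing side chain, and compound 3 `NNC(=O)COc1ccncc1-c1ccc2ccccc2c1` a related (aminocarbamoyl)methoxy group. For both of these, the result in a functional assay on HCT-116 cells (Homo sapiens) for inhibition, read by MTT assay, with a stated time of 72 h (a lower number here means a stronger inhibitor of growth, a higher number a weaker inhibitor of growth), is recorded only as "not determined" (no result reported) for compound 1 and as "not determined" (no result reported) for compound 3, so no number is known for either. Compound 2 `O=C(O)/C=C/c1ccncc1-c1ccc2ccccc2c1` bears an acrylic acid chain in their place. In this assay compound 2 reaches only a limit of the measurement, > 30000 nM, and not a number. Compound 3 thus stands nowhere on a scale: among the three entries, one is that limit of > 30000 nM in this assay, at which 1 of the 3 values shown sits, and the other two are without a number.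

Compound 4 `CCOC(=O)/C=C/c1ccncc1-c1ccc2ccccc2c1` is to be measured next. It differs from compound 3 by 2-(ethoxycarbonyl)ethenyl in place of (aminocarbamoyl)methoxy on an aromatic carbon. For the measured compounds named here, no measured step connects compound 3 to anything, so nothing can be computed for this change; the only neighbour with a result is compound 2, whose limit sets no direction. For compound 4, an expected value of about 20000 nM in this assay is estimated, within a range from 4000 nM to 100000 nM.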

Compound 4, concentration for 50% growth inhibition: 910 nM
Compound 4: the middle estimate sits 22-fold (1.34 log units) above what was measured, outside the stated range (below it).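

Compound 4 gives this series its first actual number in this assay, showing that growth inhibition can be read with a 2-(ethoxycarbonyl)ethenyl chain on this aromatic carbon, opposite the ring nitrogen. Placing an ethyl group on the acid oxygen of the chain, which turns the acid into its ethyl ester, gives an at least 32-fold lower number from compound 2 to compound 4 (1.51 log units; beyond the scatter), so this small change at the end of the chain has a large effect on the read-out. The value for compound 2 is a limit and not a number: the limit of > 30000 nM in this assay, at which 1 of the 4 values shown sits.

With no result for compound 1 or compound 3, the chains joined through an oxygen cannot be compared with the ester chain. On these data alone, it remains open whether a methyl ester, a longer ester chain or a primary amide would match the ethyl ester, and whether a saturated chain would serve as well as the one with the double bond.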